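A few compounds are considered here, and "the series" means these few. Any claim that something is new, unique, unknown or untested is made for them only; others in the source may bear on it.

Working notes on the series. Compound 1 `O=C(Nc1cccc(-n2cc(-c3ccncc3)c(-c3ccc(Cl)c(O)c3)n2)c1)Nc1ccc(Cl)c(Cl)c1` gives 1250 nM in a functional assay on UO-31 cells (Homo sapiens) for inhibition, read by sulforhodamine B assay, with a stated time of 48 h (on this read-out higher numbers stand for weaker inhibition of growth and lower numbers for stronger inhibition of growth), the highest of the three numbers measured. Compound 3 `O=C(Nc1cccc(-n2cc(-c3ccncc3)c(-c3ccc(Cl)c(O)c3)n2)c1)Nc1cc(C(F)(F)F)cc(C(F)(F)F)c1`, which carries a bis(trifluoromethyl)phenyl on the urea, gives 647 nM in this assay, a value within the scatter of compound 1. Compound 2 `COc1cc(-c2nn(-c3cccc(NC(=O)c4ccc(Cl)c(C(F)(F)F)c4)c3)cc2-c2ccncc2)ccc1Cl`, an amide rather than a urea with a methoxy on the shared core, gives 267 nM in this assay, a number beyond the scatter below compound 1.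

Compound 4 `O=C(Nc1cccc(-n2cc(-c3ccncc3)c(-c3ccc(Cl)c(O)c3)n2)c1)Nc1ccc(Cl)c(C(F)(F)F)c1` differs from compound 1 by trifluoromethyl in place of chloro on an aromatic carbon, that is, 3,4-dichlorophenyl becomes 4-chloro-3-(trifluoromethyl)phenyl. Among the measured compounds shown here, no measured step of this kind exists. The expected step of a 1.6-fold lower number from compound 1 to compound 4 (0.19 log units; within the scatter) is small, toward a lower number, and not clearly beyond the scatter. Compound 4 is expected to give about 800 nM in this assay, within 350 nM to 1800 nM.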

Compound 4, concentration for 50% growth inhibition: 777 nM
For compound 4 the middle estimate is 1.0-fold (0.01 log units) above the measured one; measured number inside the range.
By their numbers in this assay, from the lowest: compound 2; then compounds 3, 4 and 1 (each within the scatter of the next).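

At this position, ortho to a chloro group, trifluoromethyl in place of chloro gives a 1.6-fold lower number from compound 1 to compound 4 (0.21 log units; within the scatter) in this assay and so brings four heavy atoms in place of one with no step beyond the scatter. The earlier compounds shown here held no pair differing at this one place. No measurement at hand bears on a reason for this result.

On these data alone, whether an amine or a carboxylic acid at this position would stay within the scatter of compound 1 remains open. So does the effect of replacing the chloro group retained in compound 4.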